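Swapping bromo for isopropyl on the benzyl ring

A few compounds are considered here, and "the series" means these few. Any claim that something is new, unique, unknown or untested is made for them only; others in the source may bear on it.

Measured compounds:
- compound 1, `Cc1c(C2CC2)nc2ccc(-n3ccc(OCc4ccccc4)cc3=O)cn12`: 28 nM
- compound 2, `Cc1c(C2CC2)nc2ccc(-n3ccc(OCc4ccc(F)cc4)cc3=O)cn12`: 28 nM
- compound 3, `Cc1c(C2CC2)nc2ccc(-n3ccc(OCc4ccc(Br)cc4)cc3=O)cn12`: 9.3 nM

The three compounds share one core and differ only at the outer benzyl ring. In an assay on CHO cells for displacement of a labelled ligand from melanin-concentrating hormone receptor 1 (Rattus norvegicus), read by scintillation counting, with a stated time of 1 h (on this read-out lower numbers stand for stronger inhibition and higher numbers for weaker inhibition), compound 3 gives the lowest of the three numbers. The step of a 3.0-fold lower number from compound 1 to compound 3 (0.48 log units; beyond the scatter) and the step of a 3.0-fold lower number from compound 2 to compound 3 (0.48 log units; beyond the scatter) both go in the same direction and by the same amount, while the step of no change at the digits printed from compound 1 to compound 2 (within the scatter) shows no change, so compound 3 stands alone at the stronger end.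

Compound 4, `Cc1c(C2CC2)nc2ccc(-n3ccc(OCc4ccc(C(C)C)cc4)cc3=O)cn12`, takes this one step further: isopropyl in place of bromo on an aromatic carbon. For the measured compounds named here, no measured step tells how isopropyl compares with bromo here; the steps that bear on it only show that putting bromo in place of hydrogen or fluoro on that carbon helped compound 3. The expectation is therefore a number close to that of compound 3, with a modest move in either direction possible, most likely none beyond the scatter. For compound 4 the estimate in this assay is 9 nM, between 3 nM and 27 nM, which is expected to read as a 1.0-fold lower number from compound 3 to compound 4 (0.01 log units; within the scatter).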

Compound 4, half-maximal inhibitory concentration: 240 nM
Compound 4: the middle estimate sits 27-fold (1.43 log units) below what was measured; the measured number lies above the stated range.
By their numbers in this assay, from the lowest: compound 3; then compounds 1 and 2 (each within the scatter of the next); then compound 4.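

Isopropyl is the first group in this series to weaken inhibition at this ring carbon: in this assay it gives an 8.6-fold higher number from compound 1 to compound 4 (0.93 log units; beyond the scatter) and an 8.6-fold higher number from compound 2 to compound 4 (0.93 log units; beyond the scatter) when it replaces hydrogen and fluoro. Its contrast with bromo is larger still, with a 26-fold higher number from compound 3 to compound 4 (1.41 log units; beyond the scatter) for a swap of one heavy atom for three, so replacing hydrogen at this position can leave the number unchanged, lower it or raise it, depending on the group. Nothing available here explains why these groups behave so differently.

As far as these compounds go, how a methyl, a chloro or a methoxy on this carbon would compare with bromo and isopropyl remains open. So does the question of how an amine or a carboxylic acid at the same place would read.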